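Swapping the Aryl Group on a Pyrazole Urea

The source may report more compounds than this note shows. Statements on the series, on what has been measured and on what is new or still open speak of the compounds shown alone.

Three compounds sharing a urea linker and a common core have been tested in an assay on CHO-K1 cells for antagonist activity at transient receptor potential cation channel subfamily V member 1 (Homo sapiens), read by FLIPR and calcium flux, with a stated time of 6 min; a lower number here means a stronger inhibitor, a higher number a weaker inhibitor. Compound 1, `Cn1ncc2cc(NC(=O)NCc3cc(C(F)(F)F)nn3-c3cccc(Cl)c3)ccc21`, gives 61 nM. Compound 2, `CC(C)(C)c1cc(CNC(=O)Nc2cccc3[nH]ncc23)n(-c2cccc(Cl)c2)n1`, gives 0.6 nM. Compound 3, `O=C(NCc1cc(C(F)(F)F)nn1-c1ccc(Cl)cc1)Nc1cccc2[nH]ncc12`, gives 2.5 nM. Among these three numbers compound 3 holds the second highest: compound 2 is nearest with a lower number that lies beyond the scatter, and compound 1 is furthest with a higher number, also beyond the scatter.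

Compound 4, `Cc1ccc(-n2nc(C(F)(F)F)cc2CNC(=O)Nc2cccc3[nH]ncc23)cc1C`, has not yet been measured in this assay. It differs from compound 3 in one place: 3,4-dimethylphenyl in place of 4-chlorophenyl on an aromatic nitrogen. Among the measured compounds shown here, no pair of measured compounds here differs by exactly this kind of change, so there is no measured step to lean on. Both the group that leaves and the group that enters are six-membered aromatic rings of carbon only, with no hydrogen-bond donors or acceptors, and the expected step is small, within the scatter or slightly towards a higher number. The estimate for compound 4 in this assay is 4 nM, with a range from 1.2 nM to 14 nM. The expected step from compound 3 to compound 4 is a 1.6-fold higher number from compound 3 to compound 4 (0.20 log units; within the scatter).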

Compound 4, inhibition constant: 2.8 nM
Estimate against measurement, compound 4: 1.4-fold (0.15 log units) above; the range from low to high includes it.
By their numbers in this assay, from the lowest: compound 2; then compounds 3 and 4 (each within the scatter of the next); then compound 1.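

In this assay, among the compounds shown here, putting 3,4-dimethylphenyl in place of 4-chlorophenyl on the aromatic nitrogen gives a 1.1-fold higher number from compound 3 to compound 4 (0.05 log units; within the scatter) and this is the only step measured at this position. It shows that, in this pair with the trifluoromethyl group and the shared urea, the chlorine is not needed to keep the number in the low nanomolar range: an aryl ring carrying only carbon substituents serves equally well within the scatter. Nothing measured here explains why the two rings give such similar numbers, so the result records what happens at this position and offers no cause for it.

.

Going by these compounds, a single step cannot show how widely this holds, and whether a plain phenyl ring, a pyridine ring or a phenyl ring bearing a carboxylic acid or an amine would stay in the same range remains open. On these data alone, it is also open whether the same exchange would behave alike beside a tert-butyl group in place of the trifluoromethyl group, or on the core of compound 1.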